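A few compounds are considered here, and "the series" means these few. Any claim that something is new, unique, unknown or untested is made for them only; others in the source may bear on it.

Measured in an ADME assay on HEK-293T cells (Homo sapiens) for cytotoxicity, read by MTT assay, with a stated time of 48 h; on this read-out higher numbers stand for lower toxicity in this test and lower numbers for higher toxicity in this test:
- Compound 1 `Cn1cc(C2CC(c3ccccc3)=NN2C(=O)c2cccnc2)c2cc(Br)ccc21`: > 300000 nM
- Compound 2 `Cn1cc(C2CC(c3ccc(Br)cc3)=NN2C(=O)c2cccnc2)c2cc(Br)ccc21`: > 300000 nM
- Compound 3 `COc1ccc(C2=NN(C(=O)c3cccnc3)C(c3cn(C)c4ccc(Br)cc34)C2)cc1OC`: > 300000 nM

Each of these entries is a limit of the assay and not a number. Compound 3 therefore has no exact position in the series, and the whole record so far is the limit of > 300000 nM in this assay, at which 3 of the 3 values shown sit.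

Compound 4 `COc1cc(C2=NN(C(=O)c3cccnc3)C(c3cn(C)c4ccc(Br)cc34)C2)cc(OC)c1OC` differs from compound 3 by methoxy in place of hydrogen on an aromatic carbon, a change from 3,4-dimethoxyphenyl to 3,4,5-trimethoxyphenyl. Among the measured compounds shown here, three measured steps bear on it: a step that the two limits leave unreadable from compound 1 to compound 3, a step that the two limits leave unreadable from compound 2 to compound 3 and a step that the two limits leave unreadable from compound 1 to compound 2. None of them has a readable size, so they offer no measured direction for the new methoxy. All the same, the three aryl variations measured so far end at the same limit. No step beyond the usual scatter is therefore expected in this assay, and the most likely report for compound 4 is again a limit. The estimated step is a number no higher from compound 3 to compound 4 (the limit leaves the size open). For compound 4 the expected value is 300000 nM, with an estimated range from 100000 nM to 600000 nM.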

Compound 4, half-maximal cytotoxic concentration: 131000 nM
For compound 4 the middle estimate is 2.3-fold (0.36 log units) above the measured one; the measured number falls inside the stated range.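

In this assay, among the compounds shown here, the added methoxy gives the first step at this aryl position that can be read, where all earlier steps could not: an at least 2.2-fold lower number from compound 3 to compound 4 (0.35 log units; beyond the scatter). The two other aryl comparisons point the same way, with an at least 2.2-fold lower number from compound 2 to compound 4 (0.35 log units; beyond the scatter) and an at least 2.2-fold lower number from compound 1 to compound 4 (0.35 log units; beyond the scatter), so among the aryl groups shown only 3,4,5-trimethoxyphenyl brings the number under the limit. Only compound 4 carries an exact number, and the other entries stay at a single limit: the limit of > 300000 nM in this assay, at which 3 of the 4 values shown sit.

As far as these compounds go, the full size of these steps stays open, since each starts from a limit, and so does whether the methoxy itself matters or any group on that carbon would do the same. Also open, from the compounds shown here alone, is what a hydroxy, an amine, a carboxylic acid or a longer chain such as ethoxy would give there.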